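Inverting One Stereocentre: From Compound 3 to Compound 4

A few compounds are considered here, and "the series" means these few. Any claim that something is new, unique, unknown or untested is made for them only; others in the source may bear on it.

Measured so far in a functional assay on HL-60 cells (Homo sapiens) for cytotoxicity, read by WST assay, with a stated time of 48 h; on this read-out lower numbers stand for stronger inhibition and higher numbers for weaker inhibition:
compound 1 `COc1ccc(C(c2ccc(OC)c(OC)c2)[C@@H](C)[C@H](C)CO)cc1OC` gives > 100000 nM.
compound 2 `COc1ccc(C(c2ccc(OC)c(OC)c2)[C@@H](C)[C@@H](C)CO)cc1OC` gives > 100000 nM.
compound 3 `COc1ccc(C(c2ccc(OC)c(OC)c2)[C@H](C)[C@@H](C)CO)cc1OC` gives 47000 nM.

For compound 1 the value > 100000 nM is a limit of this assay, not a number. For compound 2 the value > 100000 nM is likewise a limit. Compound 3 therefore stands as the only compound with a number shown; the two other values are limits, as the limit of > 100000 nM in this assay, at which 2 of the 3 values shown sit, records. All three share the same atoms and bonds and differ only in configuration. The step that the two limits leave unreadable from compound 1 to compound 2 cannot be read, whereas an at least 2.1-fold lower number from compound 1 to compound 3 (0.32 log units; beyond the scatter) and an at least 2.1-fold lower number from compound 2 to compound 3 (0.32 log units; beyond the scatter) both show compound 3 with the lower number.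

Compound 4 `COc1ccc(C(c2ccc(OC)c(OC)c2)[C@H](C)[C@H](C)CO)cc1OC` differs from compound 3 in this way: the two compounds have the same atoms and bonds and differ only in configuration as drawn: 1 of 2 stereo elements differ; a stereocentre at a saturated chain carbon is drawn R in compound 3 and S in compound 4. The relevant precedent is an at least 2.1-fold lower number from compound 2 to compound 3 (0.32 log units; beyond the scatter), a single stereocentre change that moved the number at least modestly, and a step that the two limits leave unreadable from compound 1 to compound 2, where a single change left both values at the limit. In this assay the expected change is a 1.9-fold higher number from compound 3 to compound 4 (0.28 log units; within the scatter). Compound 4 is estimated at 90000 nM, between 30000 nM and 250000 nM.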

Compound 4, half-maximal inhibitory concentration: > 100000 nM
Compound 4 ended at the assay's limit (the forecaster's own chance of this, stated with the estimate: 55%); middle value at least 1.1-fold (0.04 log units) away from the limit.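

Compound 4 gives > 100000 nM in this assay, which is a limit of the assay and not a number. Even so, inverting this one stereocentre gives an at least 2.1-fold higher number from compound 3 to compound 4 (0.32 log units; beyond the scatter), so this position matters on compound 3 just as the other stereocentre does, and the inversion at either centre now ends at the limit. Of the four compounds, only compound 3 has a readable number, and this step can be tied to configuration alone because no atom or bond changes: the fact that compounds 3 and 4 differ only in the configuration as drawn

As far as these compounds go, the steps among compounds 1, 2 and 4 cannot be read, as all three sit at the limit, so their order stays unknown. Also open, from the compounds shown here alone, is whether the arrangement in compound 3 would keep its edge if a carboxylic acid or an amine replaced the alcohol, or with a longer chain.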